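Phenyl for methyl on the ring nitrogen of compound 3

A few compounds are considered here, and "the series" means these few. Any claim that something is new, unique, unknown or untested is made for them only; others in the source may bear on it.

Of the compounds shown here, three have numbers so far in a functional assay on cells (Panel melanoma (Carcinoma cell lines), Homo sapiens) for inhibition; on this read-out higher numbers stand for weaker inhibition of growth and lower numbers for stronger inhibition of growth. Compound 1 `Cc1ccc(/C=C2\CN(C)CC3C2=NN(c2ccccc2)C3c2ccc(C)cc2)cc1` gives 77900 nM, compound 2 `COc1ccc(/C=C2\CN(C)CC3=C2N=C(S)NC3c2ccc(OC)cc2)cc1` gives 11700 nM, and compound 3 `CN1C/C(=C\c2cccs2)C2=NN(C)C(c3cccs3)C2C1` gives 85000 nM. Compound 3 stands at the highest of the three numbers; compound 1 lies within the scatter of it, while compound 2 sits beyond the scatter at a clearly lower number, so compound 2 is the only one of the three that separates from compound 3.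

Compound 4 `CN1C/C(=C\c2cccs2)C2=NN(c3ccccc3)C(c3cccs3)C2C1` is not yet measured. It differs from compound 3 in one place: phenyl in place of methyl on an amine nitrogen in a ring. The same kind of amine-nitrogen substituent, a phenyl on an amine nitrogen in a ring, is present in compound 1, whose number lies within the scatter of compound 3, so the change from methyl to phenyl at that position has no visible effect in the data at hand. For the measured compounds named here, no step between measured compounds covers this change directly.

Expectation for compound 4: a step from compound 3 no larger than the scatter, in either direction, is expected, a 1.2-fold lower number from compound 3 to compound 4 (0.08 log units; within the scatter). Compound 4 is therefore estimated at 70000 nM, with a range of 25000 nM to 200000 nM.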

Compound 4, concentration for 50% growth inhibition: 42500 nM
For compound 4 the middle estimate is 1.6-fold (0.22 log units) above the measured one; the range from low to high includes it.
By their numbers in this assay, from the lowest: compound 2; then compounds 4, 1 and 3 (each within the scatter of the next).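

For the compounds shown here, replacing methyl with phenyl on the amine nitrogen in the five-membered ring gives, in this assay, a 2.0-fold lower number from compound 3 to compound 4 (0.30 log units; within the scatter), the first step that reads this position directly. Before it, the position could be judged only from compound 1, which differs from compound 3 in more than one place; this matched pair now shows that six heavy atoms and a six-membered aromatic ring of carbon can stand on this nitrogen, next to the ring atom that bears a thiophen-2-yl group, without a step beyond the scatter, so methyl and phenyl cannot be told apart here on this read-out. Nothing measured on these compounds accounts for this result or says what the position contributes to growth inhibition.

On these data alone, whether a benzyl group, a longer alkyl chain, or a phenyl carrying a carboxylic acid or an amine on this nitrogen would give a step beyond the scatter remains open. As far as these compounds go, the reading also rests on a single pair carrying thiophen-2-yl groups, so it is open whether phenyl for methyl reads the same with a 4-methoxyphenyl group on the ring atom next to this nitrogen.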